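The compounds below may be only part of what the source reports. "The series", "measured", "known", "first", "only" and "open" are said of these compounds alone.

Measured so far in a functional assay on PC-3 cells (Homo sapiens) for antiproliferative activity, read by MTT assay, with a stated time of 48 h; a lower number here means a stronger inhibitor, a higher number a weaker inhibitor:

- compound 1 `O=C(/C=C\Nc1ccc(F)cc1)c1cn(-c2ccccc2)nc1-c1ccccc1` gives 7980 nM
- compound 2 `O=C(/C=C\Nc1ccc(Cl)cc1)c1cn(-c2ccccc2)nc1-c1ccccc1` gives 5200 nM
- compound 3 `O=C(/C=C\Nc1ccc(F)cc1)c1cn(-c2ccccc2)nc1-c1ccc(F)cc1` gives 7900 nM

Compound 3 stands second highest of the three numbers; its nearest neighbour is compound 1, at a 1.0-fold lower number from compound 1 to compound 3 (0.00 log units; within the scatter), and its furthest is compound 2, with the two values separated by an amount that stays within the scatter. Among the measured compounds shown here, all three compounds are therefore indistinguishable in this assay on the numbers so far.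

Compound 4 `O=C(/C=C\Nc1ccc(Cl)cc1)c1cn(-c2ccccc2)nc1-c1ccc(F)cc1` is not yet measured. Against compound 3 the change is chloro in place of fluoro on an aromatic carbon. For the measured compounds named here, the one measured step that bears on it is the same exchange on the same ring, made on the pair without the added fluoro: a 1.5-fold lower number from compound 1 to compound 2 (0.19 log units; within the scatter), within the scatter. Nothing beyond the scatter is therefore expected from compound 3 to compound 4 in this assay.

The estimate for compound 4 is 5500 nM (range 2500 nM to 12000 nM), which is expected to mean a step of a 1.4-fold lower number from compound 3 to compound 4 (0.16 log units; within the scatter).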

Compound 4, half-maximal inhibitory concentration: 3800 nM
Compound 4: the middle estimate sits 1.4-fold (0.16 log units) above what was measured; the measured number falls inside the stated range.
By their numbers in this assay, from the lowest: compounds 4, 2, 3 and 1 (each within the scatter of the next, the first and the last beyond it).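

In this assay, the change of 4-fluorophenyl to 4-chlorophenyl in the amino side chain gives a 2.1-fold lower number from compound 3 to compound 4 (0.32 log units; beyond the scatter), the first step among the compounds shown to pass the scatter, and only a modest one. It does not show that the change behaves differently on the two cores, which agree within the scatter: the same change on two cores in this assay, a 1.5-fold lower number (0.19 log units; within the scatter) from compound 1 to compound 2 and a 2.1-fold lower number (0.32 log units; beyond the scatter) from compound 3 to compound 4, 1.4-fold (0.13 log units) apart, within the scatter of two such steps

Fluoro in place of hydrogen, now read with the (4-chlorophenyl)amino group in place, gives a 1.4-fold lower number from compound 2 to compound 4 (0.14 log units; within the scatter), so this change shows no readable effect with either halogen: the same change on two cores in this assay, a 1.0-fold lower number (0.00 log units; within the scatter) from compound 1 to compound 3 and a 1.4-fold lower number (0.14 log units; within the scatter) from compound 2 to compound 4, 1.4-fold (0.13 log units) apart, within the scatter of two such steps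

The compounds shown leave open whether the trend from fluoro to chloro continues to bromo or iodo at this place. They also leave open how a methoxy group, an amine or a carboxylic acid would read there.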